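Cytotoxicity of Sulfonamide Benzoxazoles on HEK293 Cells

This account rests on a few compounds, and the source may have more. Where it says the series, first, only, none or still open, it means among the compounds named here.

Compound 1 `Cc1ccc(S(=O)(=O)Nc2ccc(-c3nc4ccccc4o3)cc2)cc1`: 88000 nM
Compound 2 `C=Cc1ccc(S(=O)(=O)Nc2ccc3oc(-c4ccccc4)nc3c2)cc1`: 53000 nM
Compound 3 `C=Cc1ccc(S(=O)(=O)Nc2ccc(-c3nc4ccccc4o3)cc2)cc1`: > 100000 nM

Three measured compounds share a core and were read in an ADME assay on HEK293 cells (Homo sapiens) for cytotoxicity, read by resazurin assay, with a stated time of 48 h; on this read-out higher numbers stand for lower toxicity in this test and lower numbers for higher toxicity in this test. Compound 1 gives 88000 nM. Compound 2 gives 53000 nM, the lowest of the two plain numbers, with compound 1 nearest to it and within the scatter. For compound 3 the assay reports only a limit, > 100000 nM, because of the limit of > 100000 nM in this assay, at which 1 of the 3 values shown sits.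

For the measured compounds named here, the one measured step, an at least 1.1-fold higher number from compound 1 to compound 3 (0.05 log units; that floor lies within the scatter), lies within the scatter; it exchanges a group on the aromatic ring of the sulfonyl side, the same part of the molecule touched here.

Compound 4 `COc1ccc(Cl)cc1S(=O)(=O)Nc1ccc2oc(-c3ccccc3)nc2c1` has not yet been measured. It differs from compound 2 by 5-chloro-2-methoxyphenyl in place of 4-vinylphenyl on a sulfonyl sulfur. Going by the values given here, since the only related step stayed within the scatter, the step from compound 2 to compound 4 is expected to be a 1.1-fold higher number from compound 2 to compound 4 (0.05 log units; within the scatter), with no clear direction. Compound 4 is therefore estimated at 60000 nM, ranging from 25000 nM to 150000 nM.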

Compound 4, half-maximal cytotoxic concentration: 74000 nM
Compound 4: the middle estimate sits 1.2-fold (0.09 log units) below what was measured; low and high end bracket the measured number.
By their numbers in this assay, from the lowest: compounds 2, 4 and 1 (each within the scatter of the next). At a limit, above all of these: compound 3.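

In this assay the exchange of the whole 4-vinylphenyl for 5-chloro-2-methoxyphenyl on the sulfonyl sulfur gives a 1.4-fold higher number from compound 2 to compound 4 (0.14 log units; within the scatter) and so goes further than the earlier change of one small group on that ring, yet compound 2 and compound 4 still cannot be told apart. At this position, then, a ring carrying chlorine and methoxy, with a hydrogen-bond acceptor that 4-vinylphenyl lacks, leaves the reading within what repeated measurements would show. No measured property at hand bears on this step.

The compounds shown leave open whether an amine or a carboxylic acid on this ring would carry the number beyond the scatter. They also leave open how 5-chloro-2-methoxyphenyl would read with the rest of compound 1.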